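Ring size at the chain end and demethylase inhibition

The source may report more compounds than this note shows. Statements on the series, on what has been measured and on what is new or still open speak of the compounds shown alone.

Compound 2 `O=C(O)CCN(O)C(=O)CCCCCCCCC1CCCCC1` is one of two compounds tested in an assay on isolated protein for inhibition of lysine-specific demethylase 5A (Homo sapiens), read by coupled enzyme assay, with a stated time of 1 h; a lower number here means a stronger inhibitor, a higher number a weaker inhibitor. In this assay compound 2 gives 100000 nM, and compound 1 `O=C(O)CCN(O)C(=O)CCCCCCCCC1CC1` gives 55000 nM; these two numbers lie within the usual scatter of each other, so neither can be called the stronger inhibitor. Among the measured compounds shown here, the only measured step, a 1.8-fold higher number from compound 1 to compound 2 (0.26 log units; within the scatter), enlarges the ring at the far end of the chain and leaves the number essentially unchanged.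

Compound 3 `O=C(O)CCN(O)C(=O)CCCCCCCCC1CCCCCC1` continues in the same direction: cycloheptyl in place of cyclohexyl on a saturated chain carbon, eight bonds along the chain from a carbonyl carbon. For the measured compounds named here, the step from compound 1 to compound 2 is the one comparison that bears on this change, and it produced no shift beyond the scatter. A step of similar size, a 1.3-fold higher number from compound 2 to compound 3 (0.11 log units; within the scatter), is therefore expected for compound 3. Compound 3 is accordingly estimated to give 130000 nM in this assay, within a range from 50000 nM to 350000 nM.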

Compound 3, half-maximal inhibitory concentration: 55000 nM
Beside the measured number, compound 3's estimate is 2.4-fold (0.37 log units) above it; the measured number falls inside the stated range.
By their numbers in this assay, from the lowest: compounds 1, 3 and 2 (each within the scatter of the next).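

Cycloheptyl in place of cyclohexyl, on a saturated chain carbon, eight bonds along the chain from a carbonyl carbon, gives a 1.8-fold lower number from compound 2 to compound 3 (0.26 log units; within the scatter) in this assay and so stays within the scatter, as the earlier ring swap did. The largest swap in ring size among these compounds, cycloheptyl in place of cyclopropyl, gives no change at the digits printed from compound 1 to compound 3 (within the scatter) and so shows that even the two ends of this series cannot be told apart. Cyclopropyl, cyclohexyl and cycloheptyl therefore show no trend with ring size at this position, and no evidence on hand accounts for this flat result.

These three compounds all carry a saturated carbon ring, so they leave open whether the chain end tolerates something of a different kind, such as a phenyl ring, an amine or a carboxylic acid. They also leave open whether the ring matters at all, which a plain longer chain without any ring would help to show.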